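A few compounds are considered here, and "the series" means these few. Any claim that something is new, unique, unknown or untested is made for them only; others in the source may bear on it.

Two compounds of the series carry numbers in an assay on RPMI-8866 cells for inhibition of integrin alpha-4/beta-1 (Homo sapiens); on this read-out higher numbers stand for weaker inhibition and lower numbers for stronger inhibition. Compound 1 `O=C(O)CCNC(=O)[C@@H]1CCCN1S(=O)(=O)c1cc(Cl)cc(Cl)c1` gives 1510 nM. Compound 2 `O=C(O)C[C@@H](NC(=O)[C@@H]1CCN1S(=O)(=O)c1cc(Cl)cc(Cl)c1)c1ccc(OC2CC2)cc1` gives 0.31 nM, the lower of the two numbers, with the gap to compound 1 lying well beyond the scatter. Compound 3 `O=C(O)C[C@@H](NC(=O)[C@@H]1CCN1S(=O)(=O)c1cc(Cl)cc(Cl)c1)c1ccc(OCF)cc1` differs from compound 2 by fluoromethyl in place of cyclopropyl on an oxygen on an aromatic ring. Among the measured compounds shown here, no measured pair in this assay shows a step of this kind, so the expected step rests on the change alone: a modest weakening is expected, a 2.9-fold higher number from compound 2 to compound 3 (0.46 log units; beyond the scatter), and it may fall within the scatter. Compound 3 is expected to give 0.9 nM in this assay, within 0.3 nM to 4 nM.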

Compound 3, half-maximal inhibitory concentration: 0.72 nM
Compound 3: the middle estimate sits 1.3-fold (0.10 log units) above what was measured; the measured number falls inside the stated range.
By their numbers in this assay, from the lowest: compound 2; then compound 3; then compound 1.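

In this assay the oxygen on the aromatic ring accepts fluoromethyl in place of cyclopropyl at a modest cost (a 2.3-fold higher number from compound 2 to compound 3 (0.37 log units; beyond the scatter)). The three-membered carbon ring is therefore not needed for a low number here, as compound 3 still gives 0.72 nM. Nothing available explains the size of this step.

Going by these compounds, how a longer chain, an amine or a trifluoromethyl group would read on this oxygen stays open. With a single pair carrying this change, it is also unknown whether the step holds on other cores.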